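The compounds below may be only part of what the source reports. "The series", "measured", "known", "first", "only" and "open" are said of these compounds alone.

Measured so far:

Compound 1, `OC1CCCN(C(=S)Sc2c(-c3ccc(Br)cc3)[nH]c3ccccc23)C1`, in a functional assay on A549 cells (Homo sapiens) for inhibition, read by MTT assay, with a stated time of 72 h (a higher number here means a weaker inhibitor of growth, a lower number a stronger inhibitor of growth), gives 24000 nM.
Compound 2, `CCOC(=O)C1CCN(C(=S)Sc2c(-c3ccc(Br)cc3)[nH]c3ccccc23)CC1`, in this assay gives 34000 nM.
Compound 3, `OC1CCCN(C(=S)Sc2c(-c3ccc(Br)cc3)[nH]c3ccc(Cl)cc23)C1`, in this assay gives 29000 nM.

Compounds 1 and 3 share a core and differ in one place: chloro in place of hydrogen on an aromatic carbon. That change made a step of a 1.2-fold higher number from compound 1 to compound 3 (0.08 log units; within the scatter). Compound 2 carries a different group on the nitrogen of the saturated ring; how its core differs from that of compound 1 is not broken down here. Its value and the values of compounds 1 and 3 all lie within the usual scatter of one another, so no order among the three can be read from them.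

Compound 4, `CCOC(=O)C1CCN(C(=S)Sc2c(-c3ccc(Br)cc3)[nH]c3ccc(Cl)cc23)CC1`, has not yet been measured in this assay. It differs from compound 2 in one place: chloro in place of hydrogen on an aromatic carbon. Going by the values given here, this is the same change as the one from compound 1 to compound 3, made on a different core. Because that change gave a 1.2-fold higher number from compound 1 to compound 3 (0.08 log units; within the scatter), a step of about the same small size is expected here, a 1.2-fold higher number from compound 2 to compound 4 (0.07 log units; within the scatter), though this rests on a single pair. For compound 4 the expected value in this assay is 40000 nM, likely between 20000 nM and 80000 nM.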

Compound 4, concentration for 50% growth inhibition: 34000 nM
Compound 4: the middle estimate sits 1.2-fold (0.07 log units) above what was measured, and the stated range covers the measured number.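

Putting chloro in place of hydrogen on an aromatic carbon of the core of compound 2 gave no change at the digits printed from compound 2 to compound 4 (within the scatter) in this assay. Set beside the same change on the core of compound 1, the two steps do not differ by more than the usual variation between repeats: the same change on two cores in this assay, a 1.2-fold higher number (0.08 log units; within the scatter) from compound 1 to compound 3 and no change at the digits printed (within the scatter) from compound 2 to compound 4, 1.2-fold (0.08 log units) apart, within the scatter of two such steps. So on these two cores the change carries over in the sense that neither step can be told apart from scatter, but this does not show that chloro is without effect on other cores, since only two pairs stand behind it and neither step is large enough to reveal a real trend.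

As far as these compounds go, what remains open is whether a different group on that same aromatic carbon, such as a methoxy group or an amine, would move the number beyond the scatter. From the compounds shown here alone, it is equally open whether a carboxylic acid or a longer chain on the saturated ring would do so, and whether any of this would hold in other cell lines.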